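Replacing the 3-(methylcarbamoyl)phenyl group of compound 3

This account rests on a few compounds, and the source may have more. Where it says the series, first, only, none or still open, it means among the compounds named here.

Measured so far in a functional assay on HT-29 cells (Homo sapiens) for inhibition, read by MTT assay, with a stated time of 120 h; on this read-out lower numbers stand for stronger inhibition and higher numbers for weaker inhibition
compound 1 `O=C(/C=C/c1ccc(NC(=O)Nc2ccc(Cl)c(C(F)(F)F)c2)cc1)NC1CCC1` gives 4430 nM
compound 2 `CC(NC(=O)c1cccc(-c2ccc(NC(=O)Nc3ccc(Cl)c(C(F)(F)F)c3)cc2)c1)c1ccccc1` gives 6320 nM
compound 3 `CNC(=O)c1cccc(-c2ccc(NC(=O)Nc3ccc(Cl)c(C(F)(F)F)c3)cc2)c1` gives 29300 nM

Compound 3 has the highest number of the three and is the weakest of them in this assay by steps beyond the scatter on both sides. Compound 4 `CNC(=O)/C=C(\C)c1ccc(NC(=O)Nc2ccc(Cl)c(C(F)(F)F)c2)cc1` differs from compound 3 in one place. It carries 1-methyl-2-(methylcarbamoyl)ethenyl in place of 3-(methylcarbamoyl)phenyl on an aromatic carbon, para to a large group (1-methyl-2-(methylcarbamoyl)ethenyl in place of 3-(methylcarbamoyl)phenyl on an aromatic carbon). The methyl on the amide nitrogen stays. Within the data shown here, two measured steps bear on this change. The nearest counterpart is a 6.6-fold higher number from compound 1 to compound 3 (0.82 log units; beyond the scatter) with 3-(methylcarbamoyl)phenyl entering in place of 2-(cyclobutylcarbamoyl)ethenyl, and the new change runs roughly the other way. The second is a 4.6-fold higher number from compound 2 to compound 3 (0.67 log units; beyond the scatter) with methyl entering in place of 1-phenylethyl, and compound 4 keeps that methyl. Among the measured compounds shown here, no measured compound joins an ethenyl amide to this methyl, so the two steps cannot be separated cleanly. Only part of the first step is therefore expected to return, in the direction of a lower number. The estimated change is a 2.3-fold lower number from compound 3 to compound 4 (0.35 log units; beyond the scatter) in this account. For compound 4 the expected value is 13000 nM within an estimated range of 4500 nM to 35000 nM in this assay.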

Compound 4, half-maximal inhibitory concentration: > 50000 nM
Compound 4: no number, only a limit (the forecaster's own chance of this, stated with the estimate: 10%); middle value at least 3.8-fold (0.58 log units) from the limit.
By their numbers in this assay, from the lowest: compounds 1 and 2 (each within the scatter of the next); then compound 3. At a limit, above all of these: compound 4.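

In this assay compound 4 gives > 50000 nM, which is a limit of the assay and not a number. An ethenyl amide at this position therefore does not in itself bring the lower number seen for compound 1: an at least 11-fold higher number from compound 1 to compound 4 (1.05 log units; beyond the scatter), so the lower number depends on what differs between the two groups, the 1-methyl on the ethenyl, the cyclobutyl on the amide nitrogen, or both. Against the biaryl amide, the change brings no measurable gain, and the exact size of an at least 1.7-fold higher number from compound 3 to compound 4 (0.23 log units; that floor lies within the scatter) stays unknown, since only a floor is available.

The compounds shown leave open which of the two differences between compound 1 and compound 4 matters, as neither a 2-(methylcarbamoyl)ethenyl group lacking the 1-methyl nor a 1-methyl-2-(cyclobutylcarbamoyl)ethenyl group appears among them. They also leave open whether 1-phenylethyl on the amide nitrogen of the ethenyl series, a longer chain there, or a carboxylic acid in place of the amide would lower the number at this position.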